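Swapping Trifluoromethyl for Methyl on an Ester-Linked Ring

A few compounds are considered here, and "the series" means these few. Any claim that something is new, unique, unknown or untested is made for them only; others in the source may bear on it.

Three measured compounds share a core and differ in the aromatic part of their ester. Compound 1 `CN(C)CCC(OC(=O)c1cn(C)c2ccccc12)c1ccc(Cl)cc1` gives 104% in an assay on NIH3T3 cells with Urotensin-2 receptor (Homo sapiens) as the target (on this read-out lower numbers stand for smaller maximal responses and higher numbers for larger maximal responses), and compound 2 `Cc1ccsc1C(=O)OC(CCN(C)C)c1ccc(Cl)cc1` gives 119%. Compound 3 `CN(C)CCC(OC(=O)c1ccc(C(F)(F)F)cc1)c1ccc(Cl)cc1` gives 47%, the lowest of the three numbers; compound 1 is its nearest neighbour, higher by an amount beyond the scatter, and compound 2 lies further off still. Compound 4 `Cc1ccc(C(=O)OC(CCN(C)C)c2ccc(Cl)cc2)cc1` has not yet been measured. It differs from compound 3 in one place: methyl in place of trifluoromethyl on an aromatic carbon. As both other aryl esters reach larger maximal responses than compound 3, an upward step in this assay beyond the scatter seems plausible, though its size is uncertain. The expected step is a number 33 percentage points higher from compound 3 to compound 4 (beyond the scatter). Compound 4 is therefore estimated at 80%, within a range from 45% to 120%.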

Compound 4, largest response reached (reported as efficacy), in percent of the reference or control that the assay uses: 56%
Compound 4: the middle estimate sits 24 percentage points above what was measured; low and high end bracket the measured number.
By their numbers in this assay, from the lowest: compounds 3 and 4 (each within the scatter of the next); then compound 1; then compound 2.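

In this assay, methyl in place of trifluoromethyl at this position gives a number 9 percentage points higher from compound 3 to compound 4 (within the scatter) and so does not separate the two groups. Changing the whole ring has a far larger effect, as 4-methylphenyl in place of 3-methylthiophen-2-yl on the carbonyl carbon gives a number 63 percentage points lower from compound 2 to compound 4 (beyond the scatter) in the same read-out. No evidence is available to explain either step. Going by these compounds, it remains open whether an amine or a hydroxyl group at this position would shift the maximal response. Also open, on these data alone, is whether a phenyl ring with only hydrogen there would match compound 3 and compound 4.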